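A few compounds are considered here, and "the series" means these few. Any claim that something is new, unique, unknown or untested is made for them only; others in the source may bear on it.

Measured so far in an assay on HEK293 cells for displacement of a labelled ligand from metabotropic glutamate receptor 5 (Homo sapiens), with a stated time of 2 h; a lower number here means a stronger inhibitor, a higher number a weaker inhibitor: compound 1 `CN1CCc2nc(C#Cc3cccc(Cl)c3)ccc2C1=O` gives 250 nM; compound 2 `CN1CCc2nc(C#Cc3ccc(Cl)cc3)ccc2C1=O` gives 6150 nM; compound 3 `O=C1c2ccc(C#Cc3cccc(Cl)c3)nc2CCN1C1CCCC1` gives 5230 nM.

Two single changes start from compound 1. One is 4-chlorophenyl in place of 3-chlorophenyl on a triple-bonded carbon, which produced a 25-fold higher number from compound 1 to compound 2 (1.39 log units; beyond the scatter). The other is how the two cores differ, (cyclopentyl in place of methyl on an amide-type nitrogen in a ring), which produced a 21-fold higher number from compound 1 to compound 3 (1.32 log units; beyond the scatter). Compound 2 and compound 3 lie within the scatter of each other.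

Compound 4 `O=C1c2ccc(C#Cc3ccc(Cl)cc3)nc2CCN1C1CCCC1` is not yet measured. Going by the values given here, it differs from compound 3 by 4-chlorophenyl in place of 3-chlorophenyl on a triple-bonded carbon, the same change as the one from compound 1 to compound 2, at the same place on the triple-bonded carbon. From compound 3 the step is expected to be an 11-fold higher number from compound 3 to compound 4 (1.06 log units; beyond the scatter), because the same change gave a 25-fold higher number from compound 1 to compound 2 (1.39 log units; beyond the scatter). Compound 4 is therefore expected near 60000 nM, likely between 12000 nM and 300000 nM, with a fair chance that this assay reports only a limit.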

Compound 4, inhibition constant: > 32000 nM
Compound 4 ended at the assay's limit; the forecaster's own chance of this, stated with the estimate: 45%; the middle value lies beyond the limit too.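

In this assay both changes keep their direction on the second core, read against the limit reached by compound 4: 4-chlorophenyl in place of 3-chlorophenyl gives an at least 6.1-fold higher number from compound 3 to compound 4 (0.78 log units; beyond the scatter) and cyclopentyl in place of methyl gives an at least 5.2-fold higher number from compound 2 to compound 4 (0.71 log units; beyond the scatter). Whether the 4-chlorophenyl change keeps its size from one core to the other is not shown: the same change on two cores in this assay, a 25-fold higher number (1.39 log units; beyond the scatter) from compound 1 to compound 2 and an at least 6.1-fold higher number (0.78 log units; beyond the scatter) from compound 3 to compound 4; the limit leaves it open whether they differ. The same question stays unanswered for the cyclopentyl change: the same change on two cores in this assay, a 21-fold higher number (1.32 log units; beyond the scatter) from compound 1 to compound 3 and an at least 5.2-fold higher number (0.71 log units; beyond the scatter) from compound 2 to compound 4; the limit leaves it open whether they differ.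

As far as these compounds go, the true value of compound 4 remains open, as only a limit is available. Also open, from the compounds shown here alone, is whether the same pattern holds with an ethyl group or a longer chain on the amide-type nitrogen, or with a nitrile in place of chlorine.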